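Trimethoxyphenyl amides: from chloroacetyl to pentanoyl

The source may report more compounds than this note shows. Statements on the series, on what has been measured and on what is new or still open speak of the compounds shown alone.

The measured compounds and their values in a functional assay on MGC-803 cells (Homo sapiens) for inhibition, read by MTT assay, with a stated time of 48 h; on this read-out lower numbers stand for stronger inhibition and higher numbers for weaker inhibition:
compound 1, `COc1ccc(CN(C(=O)CCl)c2cc(OC)c(OC)c(OC)c2)cc1O`, 84 nM;
compound 2, `C/C=C/C(=O)N(Cc1ccc(OC)c(Br)c1)c1cc(OC)c(OC)c(OC)c1`, 6430 nM;
compound 3, `C/C=C/C(=O)N(Cc1ccc(OC)cc1)c1cc(OC)c(OC)c(OC)c1`, 450 nM.

Among the three, compound 1 gives the lowest number. Compound 3 is the nearest to it, and compound 2 is furthest away. Within the data shown here, the one single-point step in the set, a 14-fold lower number from compound 2 to compound 3 (1.15 log units; beyond the scatter), concerns the benzyl ring and not the amide chain. Compound 1 and compound 3 differ in two places at once, so their values only show that compound 1 sits well below compound 3 without saying which change carries the gap.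

Compound 4, `CCCCC(=O)N(Cc1ccc(OC)c(O)c1)c1cc(OC)c(OC)c(OC)c1`, keeps the core and the hydroxylated benzyl of compound 1 but changes the acyl chain: propyl in place of chloro on a saturated chain carbon bound to a carbonyl carbon. Among the measured compounds shown here, no measured step touches this position, so the expectation rests only on the shared part with compound 1. Without support from a measured step, the chain change is estimated to give a 9.5-fold higher number from compound 1 to compound 4 (0.98 log units; beyond the scatter), a weaker number, with wide uncertainty. Compound 4 is therefore expected at about 800 nM, in a range from 150 nM to 4500 nM.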

Compound 4, half-maximal inhibitory concentration: 66 nM
Compound 4: middle estimate off by 12-fold (1.08 log units), on the high side, outside the stated range (below it).
By their numbers in this assay, from the lowest: compounds 4 and 1 (each within the scatter of the next); then compound 3; then compound 2.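

In this assay, among these compounds, the exchange of chloro for propyl on a saturated chain carbon bound to a carbonyl carbon is the first measured step at this position (a 1.3-fold lower number from compound 1 to compound 4 (0.10 log units; within the scatter)). With the shared core and the hydroxylated benzyl held fixed, the chloroacetyl chain of compound 1 and the pentanoyl chain of compound 4 cannot be told apart, so chloro is not needed for a number at this level in this pair. No measured evidence accompanies this result to explain why the two chains read alike.

The compounds shown leave open whether the same holds on a benzyl ring without the hydroxyl. They also leave open whether a longer chain, or an amine or a carboxylic acid at the end of the butyl chain, would keep a number at this level.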